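Notes on compound 3: an aryl group returns to the nitrogen

The source may hold more compounds than are shown below. What is called first, only, known or untested is meant among the compounds shown, and "the series" means these compounds.

Compound 1 `COC(=O)CN(C)c1nc(Nc2ccc(Cl)cc2)ncc1[N+](=O)[O-]` in a functional assay on HepG2 cells (Homo sapiens) for antiproliferative activity, read by MTT assay, with a stated time of 48 h (a higher number here means a weaker inhibitor, a lower number a stronger inhibitor), gives 49800 nM.
Compound 2 `COC(=O)CN(C)c1nc(NCc2ccccc2)ncc1[N+](=O)[O-]` in this assay gives > 100000 nM, which is a limit of the assay and not a number.

Compound 2 therefore stands only at a limit in this assay; the measured compounds place it no closer than that, and the step to it from the aryl analogue is known only as a floor: an at least 2.0-fold higher number from compound 1 to compound 2 (0.30 log units; that floor lies within the scatter). That floor rests on (the limit of > 100000 nM in this assay, at which 1 of the 2 values shown sits).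

Compound 3 `COC(=O)CN(C)c1nc(Nc2cccc(OC)c2)ncc1[N+](=O)[O-]` is not yet measured. The change from compound 2 to compound 3 is 3-methoxyphenyl in place of benzyl on a nitrogen on an aromatic ring. Going by the values given here, the only measured step that bears on it is the one just named, which ran in the opposite sense, from an aryl group on that nitrogen to benzyl. Compound 3 puts an aryl group back on the same nitrogen, so in this assay a step downward, toward the region of compound 1, is expected for compound 3, of about an at least 1.6-fold lower number from compound 2 to compound 3 (0.22 log units; that floor lies within the scatter). The methoxy group is not the chloro group of compound 1, so the expectation stays wide. For compound 3 the estimate is 60000 nM, between 25000 nM and 150000 nM.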

Compound 3, half-maximal inhibitory concentration: 73400 nM
For compound 3 the middle estimate is 1.2-fold (0.09 log units) below the measured one, within the range that was stated.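

In this assay, going by these compounds alone, a second aryl group on this nitrogen now allows the first comparison between two aryl compounds: a 1.5-fold higher number from compound 1 to compound 3 (0.17 log units; within the scatter). 3-Methoxyphenyl and 4-chlorophenyl therefore cannot be told apart here, so this pair gives no order between the two aryl groups, even though they differ in their atoms and in the hydrogen-bond acceptor counted for 3-methoxyphenyl. Replacing benzyl with 3-methoxyphenyl gives an at least 1.3-fold lower number from compound 2 to compound 3 (0.13 log units; that floor lies within the scatter), and since that floor is printed as within the scatter, the pair does not separate an aryl group from benzyl on this nitrogen, and the value for compound 2 is a limit of the assay and not a number: the limit of > 100000 nM in this assay, at which 1 of the 3 values shown sits.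

The compounds shown leave open whether any substituent on the aryl ring matters, since an unsubstituted phenyl or a 4-methoxyphenyl group would be needed to separate the effect of the substituent from that of its place on the ring. They also leave open how the read-out responds to changes elsewhere on the shared core, such as a carboxylic acid in place of the methyl ester or an amine in place of the nitro group.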